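Adding a Second Bromo to a Dibrominated Hydrazone Series

The source may report more compounds than this note shows. Statements on the series, on what has been measured and on what is new or still open speak of the compounds shown alone.

Compound 1, `COc1cc(/C=N/Nc2nc(-c3ccc(C(F)(F)F)cc3)cs2)c(Br)c(Br)c1OC`, gives > 100000 nM in an ADME assay on HUVEC cells (Homo sapiens) for inhibition, read by MTT assay, with a stated time of 48 h (on this read-out lower numbers stand for stronger inhibition and higher numbers for weaker inhibition), and this value is a limit of the assay rather than a number.
Compound 2, `COc1cc(/C=N/Nc2nc(-c3cc(C(F)(F)F)cc(C(F)(F)F)c3)cs2)cc(Br)c1OC`, gives > 100000 nM in this assay, again only a limit.
Compound 3, `COc1cc(/C=N/Nc2nc(-c3ccc(C(F)(F)F)cc3)cs2)cc(Br)c1OC`, gives > 100000 nM in this assay, also a limit.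

Going by the values given here, the one change measured twice in this set is the step from compound 3 to compound 1, which is a step that the two limits leave unreadable from compound 3 to compound 1. The change made there is bromo in place of hydrogen on an aromatic carbon. Its size stays hidden because of the limit of > 100000 nM in this assay, at which 3 of the 3 values shown sit, so nothing can be said about whether the added bromo helps or hurts.

Compound 2 and compound 3 share a common framework but differ in more than one place; the difference between the two cores is not broken down here.

Compound 4, `COc1cc(/C=N/Nc2nc(-c3cc(C(F)(F)F)cc(C(F)(F)F)c3)cs2)c(Br)c(Br)c1OC`, has not yet been tested in this assay. It differs from compound 2 by bromo in place of hydrogen on an aromatic carbon, and the place of this change is word for word the same as in the step from compound 3 to compound 1, so it is the same change. Since that earlier step could not be read, and since compound 2 gives only a limit at > 100000 nM, the expected step that the limit leaves unreadable from compound 2 to compound 4 rests on nothing more than the limits seen so far. Compound 4 is therefore expected to give about 150000 nM in this assay, most likely again as a limit, with a plausible range from 50000 nM to 500000 nM.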

Compound 4, half-maximal inhibitory concentration: > 100000 nM
Compound 4: no number, only a limit; the forecaster's own chance of this, stated with the estimate: 85%; the middle value lies beyond the limit too.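

The step from compound 2 to compound 4 cannot be read, so the size of this bromo change stays hidden, because both compounds give only a limit in this assay: the limit of > 100000 nM in this assay, at which 4 of the 4 values shown sit.

The compounds shown leave open whether bromo in place of hydrogen changes inhibition at all, in either pair, and how strongly any of the four compounds inhibits in numbers.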